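The source may report more compounds than this note shows. Statements on the series, on what has been measured and on what is new or still open speak of the compounds shown alone.

Within the data shown here, compound 3 `O=S(=O)(c1cc(Cl)cc(Cl)c1)c1cnc2cc(F)ccc2c1-c1cccc(F)c1` gives 0.41 mL/min in an ADME assay on microsomes from liver (Homo sapiens) for metabolic stability, tested at 2.5 uM (on this read-out lower numbers stand for slow clearance and higher numbers for fast clearance), the lowest of the three numbers so far. Compound 1 `COc1ccc(-c2c(S(=O)(=O)c3ccc(OC)cc3)cnc3cc(F)ccc23)cc1` gives 1.18 mL/min and compound 2 `Cc1ccc(S(=O)(=O)c2cnc3cc(F)ccc3c2-c2cccc(F)c2)cc1C` gives 3.71 mL/min in this assay. Compound 4 `COc1ccc(S(=O)(=O)c2cnc3cc(F)ccc3c2-c2cccc(F)c2)cc1` differs from compound 3 in one place: 4-methoxyphenyl in place of 3,5-dichlorophenyl on a sulfonyl sulfur. Among the measured compounds shown here, the only measured step at that place is a 9.0-fold lower number from compound 2 to compound 3 (0.96 log units; beyond the scatter), a modest but clear shift, so the group on the sulfonyl sulfur does matter here. Compound 1 also carries 4-methoxyphenyl on a sulfonyl sulfur, though it differs from compound 4 elsewhere, and its value sits between those of compound 3 and compound 2. Compound 4 is therefore expected to move upward from compound 3, by a 3.7-fold higher number from compound 3 to compound 4 (0.56 log units; beyond the scatter), to an estimate of 1.5 mL/min, within a range of 0.6 mL/min to 3.7 mL/min.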

Compound 4, intrinsic clearance in a liver preparation (reported as CLH), per the amount of preparation that the assay uses: 2.94 mL/min
For compound 4 the middle estimate is 2.0-fold (0.29 log units) below the measured one, and the stated range covers the measured number.
By their numbers in this assay, from the lowest: compound 3; then compound 1; then compounds 4 and 2 (each within the scatter of the next).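

In this assay the sulfonyl sulfur position is sensitive to the change to 4-methoxyphenyl, with a 7.2-fold higher number from compound 3 to compound 4 (0.86 log units; beyond the scatter) and so a clear loss of the low number seen with 3,5-dichlorophenyl. Against 3,4-dimethylphenyl the same group gives a 1.3-fold lower number from compound 2 to compound 4 (0.10 log units; within the scatter) and the two are not told apart, so among these three groups only 3,5-dichlorophenyl stands apart. The aromatic carbon position also counts, as 3-fluorophenyl in place of 4-methoxyphenyl gives a 2.5-fold higher number from compound 1 to compound 4 (0.40 log units; beyond the scatter) and no available data explain any of these shifts. From the compounds shown here alone, whether 4-chlorophenyl or pyridyl on the sulfonyl sulfur would stand with compound 3 or with compound 4 remains open.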